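The source may report more compounds than this note shows. Statements on the series, on what has been measured and on what is new or still open speak of the compounds shown alone.

Measured so far:
compound 1, `CC(C)(CCCOc1ccc(/C=C/c2ccccc2)cc1)C(=O)O`, in an ADME assay for solubility, read by spectrophotometry, using PAMPA, measured as kinetic solubility, with a stated time of 5 h, at pH 6.8; a lower number here means a less soluble compound, a higher number a more soluble compound: 13.6 ug/mL
compound 2, `CC(C)(Oc1ccc(CCCOc2ccc(/C=C/c3ccccc3)cc2)cc1)C(=O)O`, in this assay: 44.3 ug/mL

Going by the values given here, of these two numbers, compound 2 stands highest; compound 1 is the only other compound, and the gap between them lies beyond the usual scatter of repeated measurements. Compound 3, `CC(C)(Oc1ccc(CCCOc2ccc(C(=O)/C=C/c3ccccc3)cc2)cc1)C(=O)O`, is not yet measured. It differs from compound 2 in one place: (2-phenylethenyl)carbonyl in place of 2-phenylethenyl on an aromatic carbon. Among the compounds with values here, no measured pair shows this particular change, so the size of the step cannot be read off from the two compounds above. The entering group keeps the same aromatic ring and double bond and adds one carbonyl, counted as one hydrogen-bond acceptor, while the acid and the ether oxygens of the shared core remain. On that basis the step from compound 2 is expected to be small, upward if anything, and probably not beyond the scatter. Compound 3 is therefore estimated at 60 ug/mL, with a range from 25 ug/mL to 140 ug/mL. That estimate means an expected step of a 1.4-fold higher number from compound 2 to compound 3 (0.13 log units; within the scatter).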

Compound 3, solubility in the ADME assay: 68.4 ug/mL
For compound 3 the middle estimate is 1.1-fold (0.06 log units) below the measured one, and the stated range covers the measured number.
By their numbers in the ADME assay, from the lowest: compound 1; then compounds 2 and 3 (each within the scatter of the next).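

Placing (2-phenylethenyl)carbonyl instead of 2-phenylethenyl on this aromatic carbon, para to a large group, gives in the ADME assay a 1.5-fold higher number from compound 2 to compound 3 (0.19 log units; within the scatter), with compound 2 at 44.3 ug/mL and compound 3 at 68.4 ug/mL. In a physicochemical assay for solubility, read by spectrophotometry, measured as thermodynamic solubility, with a stated time of 24 h, at pH 6.8 (on this read-out higher numbers stand for higher solubility and lower numbers for lower solubility), which follows solubility over a longer stated time, the same change gives a 1.7-fold lower number from compound 2 to compound 3 (0.24 log units; within the scatter), with compound 2 at 27.9 ug/mL and compound 3 at 16 ug/mL, so neither assay separates the two compounds once the usual scatter of repeated measurements is taken into account. This is the first direct look at a single change at this position, and it shows that the larger group with its added carbonyl, counted as one hydrogen-bond acceptor, can enter without a step beyond the scatter in either assay; no measurement shown gives a reason for these results.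

On these data alone, all of this rests on one pair of compounds, so it remains open whether the same holds for other cores or for a different group on this aromatic carbon, such as an amine, a carboxylic acid or a longer chain. It is also open whether the carbonyl or the double bond of the entering group matters more, since a group carrying only one of them in this place is not among the compounds shown.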